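A few compounds are considered here, and "the series" means these few. Any claim that something is new, unique, unknown or untested is made for them only; others in the source may bear on it.

Of the compounds shown here, two sharing one core have so far been tested in a functional assay on MDA-MB-231 cells (Homo sapiens) for inhibition, read by MTT assay, with a stated time of 72 h; a higher number here means a weaker inhibitor, a lower number a stronger inhibitor. Compound 1, `C=CC(=O)Nc1cccc(NC(=O)CSc2nc(Nc3ccccc3C)c3ccccc3n2)c1`, gives 20400 nM. Compound 2, `C=CC(=O)Nc1cccc(NC(=O)CSc2nc(Nc3ccc(F)cc3)c3ccccc3n2)c1`, gives 9490 nM, the lowest of the two numbers, and its nearest neighbour is compound 1. Going by the values given here, the single step between them, a 2.1-fold lower number from compound 1 to compound 2 (0.33 log units; beyond the scatter), comes from putting 4-fluorophenyl in place of 2-methylphenyl on the nitrogen attached to the core.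

Compound 3, `C=CC(=O)Nc1cccc(NC(=O)CSc2nc(Nc3ccc(CC)cc3)c3ccccc3n2)c1`, keeps everything of compound 2 except one group on the outer ring: ethyl in place of fluoro on an aromatic carbon. Among the compounds with values here, no measured step replaces a fluoro with an ethyl, so nothing here speaks directly to this change. Within the data shown here, the only step that touches the same part of the molecule, from compound 1 to compound 2, was modest in size and involved a different swap. With no direct guide, the expectation is a move in this assay no larger than the usual scatter, in either direction. Compound 3 is therefore estimated at 11000 nM, with a range from 4000 nM to 35000 nM. The expected step is a 1.2-fold higher number from compound 2 to compound 3 (0.06 log units; within the scatter).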

Compound 3, half-maximal inhibitory concentration: 14400 nM
Beside the measured number, compound 3's estimate is 1.3-fold (0.12 log units) below it, and the stated range covers the measured number.
By their numbers in this assay, from the lowest: compounds 2, 3 and 1 (each within the scatter of the next, the first and the last beyond it).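

In this assay the swap of fluoro for ethyl, on an aromatic carbon para to a large group, gives a 1.5-fold higher number from compound 2 to compound 3 (0.18 log units; within the scatter) and so stays inside the normal noise of the measurement, even though ethyl brings two heavy atoms where fluoro had one. This shows that a small carbon chain can sit at this position of the outer ring without a clear loss or gain, which the earlier pair could not show, since its step changed both the group and where it sat. Going by these compounds alone, the second new comparison, a 1.4-fold lower number from compound 1 to compound 3 (0.15 log units; within the scatter), is also within the scatter, so 4-ethylphenyl cannot be told apart from either 2-methylphenyl or 4-fluorophenyl, and the one clear step remains the one between the latter two; nothing measured alongside these numbers offers an explanation for this.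

The compounds shown leave open whether a longer chain such as butyl, or a group of another kind such as an amine or a carboxylic acid, would be accommodated equally well at this position. They also leave open how a methyl on the same carbon would compare, which would separate the effect of the group's place from that of its length.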